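Swapping the sulfonamide substituent: an oxetane for a hydroxypyrrolidine

A few compounds are considered here, and "the series" means these few. Any claim that something is new, unique, unknown or untested is made for them only; others in the source may bear on it.

Measured compounds:
compound 1 `O=S(=O)(NCCO)c1cccc(-c2ccc3nccc(-c4ccc(OC(F)(F)F)cc4)c3n2)c1`, < 5000 nM
compound 2 `O=S(=O)(NCC1COC1)c1cccc(-c2ccc3nccc(-c4ccncc4)c3n2)c1`, 20000 nM

Within the data shown here, in a physicochemical assay for solubility, read by HPLC, using the shake flask method, measured as kinetic solubility, with a stated time of 20 h, at pH 6.5, tested at 200 uM (on this read-out higher numbers stand for higher solubility and lower numbers for lower solubility), compound 2 gives 20000 nM, the only number reported. For compound 1 the read-out is a limit, (the limit of < 5000 nM in this assay, at which 1 of the 2 values shown sits), not a number. Compound 3 `O=S(=O)(c1cccc(-c2ccc3nccc(-c4ccncc4)c3n2)c1)N1CC[C@H](O)C1` differs from compound 2 in one place: 3-hydroxypyrrolidin-1-yl in place of ((oxetan-3-yl)methyl)amino on a sulfonyl sulfur. Among the measured compounds shown here, no step between measured compounds is available to calibrate this change, so a shift no larger than the usual scatter is expected in this assay, in either direction. For compound 3 the expected step is a 1.3-fold lower number from compound 2 to compound 3 (0.12 log units; within the scatter), giving an estimate of 15000 nM, with a range from 5000 nM to 45000 nM.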

Compound 3, solubility: 20000 nM
The estimate for compound 3 lay 1.3-fold (0.12 log units) below the measured number, within the range that was stated.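

In this assay there is no change at the digits printed from compound 2 to compound 3 (within the scatter), the first step read at this position, with 3-hydroxypyrrolidin-1-yl in place of ((oxetan-3-yl)methyl)amino on a sulfonyl sulfur. This read-out thus does not separate these two groups, which share the same heavy atom count but differ in ring size and in the defined stereocentre. Nothing measured here bears on a cause for this step. From the compounds shown here alone, whether a piperazine or a carboxylic acid at this sulfur would read the same stays open, as does the mirror-image 3-hydroxypyrrolidin-1-yl group.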